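The source may report more compounds than this note shows. Statements on the series, on what has been measured and on what is new or still open speak of the compounds shown alone.

Measured so far:
compound 1 `COc1ccc(/C=N/NC(=O)Nc2ccc(Oc3ccnc(-c4nncn4CCN(C)C)c3)c(F)c2)c(OC)c1` — 1570 nM
compound 2 `CN(C)CCn1cnnc1-c1cc(Oc2ccc(NC(=O)N/N=C/c3ccccc3O[N+](=O)[O-])cc2F)ccn1` — 1270 nM

Both numbers come from a functional assay on NCI-H460 cells (Homo sapiens) for cytotoxicity, read by MTT assay, with a stated time of 72 h; a lower number here means a stronger inhibitor, a higher number a weaker inhibitor. Among the measured compounds shown here, compound 2 holds the lowest of the two numbers in this assay, but its only neighbour, compound 1, sits within the scatter of it: the single measured step, a 1.2-fold lower number from compound 1 to compound 2 (0.09 log units; within the scatter), shows that exchanging the aryl group on the carbon with a double bond to nitrogen left the number essentially unchanged.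

Compound 3 `COc1ccc(/C=N/NC(=O)Nc2ccc(Oc3ccnc(-c4nncn4CCN(C)C)c3)c(F)c2)cc1O` is not yet measured. Its change from compound 2 is 3-hydroxy-4-methoxyphenyl in place of 2-(nitrooxy)phenyl on a carbon with a double bond to nitrogen. The entering 3-hydroxy-4-methoxyphenyl group stands closer in build to the 2,4-dimethoxyphenyl of compound 1 than to the 2-(nitrooxy)phenyl of compound 2. For the measured compounds named here, the only step bearing on this change, a 1.2-fold lower number from compound 1 to compound 2 (0.09 log units; within the scatter), lies within the scatter, so in this assay no step beyond the scatter is expected in either direction, giving an expected 1.2-fold higher number from compound 2 to compound 3 (0.07 log units; within the scatter). Compound 3 is therefore estimated at 1500 nM, with a range from 700 nM to 3500 nM.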

Compound 3, half-maximal inhibitory concentration: 620 nM
Compound 3: the middle estimate sits 2.4-fold (0.38 log units) above what was measured, outside the stated range (below it).
By their numbers in this assay, from the lowest: compound 3; then compounds 2 and 1 (each within the scatter of the next).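

In this assay the aryl group on the carbon with a double bond to nitrogen can shift the number after all: the 3-hydroxy-4-methoxyphenyl group gives a 2.0-fold lower number from compound 2 to compound 3 (0.31 log units; beyond the scatter) and a 2.5-fold lower number from compound 1 to compound 3 (0.40 log units; beyond the scatter), both modest, whereas the earlier step stayed within the scatter. Compound 3 thus stands apart from both earlier compounds, and the position is not indifferent to the aryl group it carries. The entering group has a hydrogen-bond donor that 2-(nitrooxy)phenyl lacks, but no evidence at hand ties the step to this or any other feature of the group.

Open, going by these compounds, is whether the hydroxy group, the methoxy group or their combination carries the step. Also open, on these data alone, is how an amine or a carboxylic acid in place of that hydroxy group would read.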